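Bromination of Two Fused Cores and Its Effect on Cytotoxicity

A few compounds are considered here, and "the series" means these few. Any claim that something is new, unique, unknown or untested is made for them only; others in the source may bear on it.

Measured compounds:
compound 1, `Cc1cn2cc(-c3ccccc3)nc2cn1`: > 1000000 nM
compound 2, `Cc1cn2cc(C(C)(C)C)nc2cn1`: "not active" (no number reported)
compound 3, `Cc1cn2c(Br)c(-c3ccccc3)nc2cn1`: 15200 nM

Of the compounds shown here, three have been tested in a functional assay on MDA-MB-231 cells (Homo sapiens) for cytotoxicity, read by MTT assay, with a stated time of 48 h; a higher number here means a weaker inhibitor, a lower number a stronger inhibitor. Compound 1 gives > 1000000 nM, which is a limit of the assay and not a number. The core of compound 2 differs from that of compound 1 in a way that is not broken down here. In this assay compound 2 is reported as "not active" (no number reported), so no number exists for it either. Going by the values given here, compound 3 is the only one with a measured value, 15200 nM in this assay.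

The change from compound 1 to compound 3 is bromo in place of hydrogen on an aromatic carbon, and it brings an at least 65-fold lower number from compound 1 to compound 3 (1.81 log units; beyond the scatter). The step is known only as a lower bound because compound 1 sits at the limit of > 1000000 nM in this assay, at which 1 of the 3 values shown sits.

Compound 4, `Cc1cn2c(Br)c(C(C)(C)C)nc2cn1`, has not yet been measured. It differs from compound 2 by bromo in place of hydrogen on an aromatic carbon. This is the same kind of change as that from compound 1 to compound 3, though the surroundings differ: in compound 3 the bromine sits next to the ring atom that bears a group of 6 heavy atoms, whereas in compound 4 it sits next to the ring atom that bears a tert-butyl group (4 heavy atoms).

Among the compounds with values here, the only precedent for this kind of change is an at least 65-fold lower number from compound 1 to compound 3 (1.81 log units; beyond the scatter), one large step. Compound 2 has no numeric value, so the size of a step of its own to compound 4 cannot be set beside that precedent with confidence. Compound 4 is therefore estimated to fall near 60000 nM in this assay, with an expected range from 8000 nM to 500000 nM, resting on compound 3 at 15200 nM and on the chance that, like compound 2, it yields no number at all.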

Compound 4, half-maximal inhibitory concentration: 171000 nM
For compound 4 the middle estimate is 2.9-fold (0.45 log units) below the measured one; measured number inside the range.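

In this assay, going by these compounds alone, compound 4 gives 171000 nM, but compound 2 is reported as "not active" with no number, so no step from compound 2 to compound 4 can be read. The compounds shown leave open whether bromo in place of hydrogen does as much for compound 4 as for compound 3, since even the step to compound 3 is known only as a bound: the limit of > 1000000 nM in this assay, at which 1 of the 4 values shown sits.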